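Extending the ring amine substituent in a neuropeptide Y ligand series

The compounds below may be only part of what the source reports. "The series", "measured", "known", "first", "only" and "open" are said of these compounds alone.

Compound 1: `Cc1cccc2c1nc(COc1ccc(Cl)cc1)n2CCCC1CCN(C)CC1`, 52 nM
Compound 2: `Cc1cccc2c1nc(COc1ccc(Cl)cc1)n2CCCC1CCN(CCC(C)C)CC1`, 11 nM
Compound 3: `CCOC(=O)CN1CCC(CCCn2c(COc3ccc(Cl)cc3)nc3c(C)cccc32)CC1`, 427 nM

Of the compounds shown here, three have been measured in an assay on AV12 cells for binding affinity to Neuropeptide Y receptor type 1 (Homo sapiens); a higher number here means a weaker inhibitor, a lower number a stronger inhibitor. Compound 1 stands second highest of the three numbers. Its nearest neighbour is compound 2, reached by a 4.7-fold lower number from compound 1 to compound 2 (0.67 log units; beyond the scatter). The furthest is compound 3, reached by an 8.2-fold higher number from compound 1 to compound 3 (0.91 log units; beyond the scatter). Between those two, the change from compound 2 to compound 3 produced a 39-fold higher number from compound 2 to compound 3 (1.59 log units; beyond the scatter).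

Compound 4, `Cc1cccc2c1nc(COc1ccc(Cl)cc1)n2CCCC1CCN(CC(=O)N2CCCCC2)CC1`, has not yet been measured in this assay. It differs from compound 1 in one place: (piperidin-1-yl)carbonyl in place of hydrogen on a saturated chain carbon bound to an amine nitrogen in a ring. The group that enters carries a carbonyl, as does the ethoxycarbonyl group of compound 3, and the step from compound 1 to compound 3 is the one that bears most directly on this change. That step was a modest rise in the number, whereas the isobutyl of compound 2 brought a modest fall. Since the group entering in compound 4 resembles that of compound 3 more than that of compound 2, a rise is expected for compound 4, most likely of a size like that seen for compound 3, given as a 4.8-fold higher number from compound 1 to compound 4 (0.68 log units; beyond the scatter). In this assay compound 4 is therefore estimated at 250 nM, with a range from 80 nM to 800 nM.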

Compound 4, inhibition constant: 136 nM
For compound 4 the middle estimate is 1.8-fold (0.26 log units) above the measured one; low and high end bracket the measured number.
By their numbers in this assay, from the lowest: compound 2; then compound 1; then compound 4; then compound 3.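

In this assay, the (piperidin-1-yl)carbonyl group also raises the number, with a 2.6-fold higher number from compound 1 to compound 4 (0.42 log units; beyond the scatter), so among these compounds both carbonyl-bearing groups on the saturated chain carbon bound to an amine nitrogen in a ring go the same way, and the isobutyl of compound 2 goes against them. The carbonyl alone does not set the value, since piperidin-1-yl in place of ethoxy on a carbonyl carbon gives a 3.1-fold lower number from compound 3 to compound 4 (0.50 log units; beyond the scatter) and so shows that the group on that carbon also counts. Even so, the amide stays far from the isobutyl, with a 12-fold higher number from compound 2 to compound 4 (1.09 log units; beyond the scatter), which is a larger gap than the one separating the two carbonyl-bearing groups.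

As far as these compounds go, what a carboxylic acid or a primary amide would give at this place remains open, as does the effect of a morpholine amide on the same carbonyl carbon. From the compounds shown here alone, it is also open whether a longer chain than the isobutyl of compound 2 would lower the number further. The data offer no evidence that explains any of these differences.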